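From ethyl to methyl ester at compound 3

The compounds below may be only part of what the source reports. "The series", "measured", "known", "first", "only" and "open" are said of these compounds alone.

Measured in a functional assay on MCF7 cells (Homo sapiens) for cytotoxicity, read by MTT assay, with a stated time of 72 h (a higher number here means a weaker inhibitor, a lower number a stronger inhibitor), so far:

Compound 1 `CCOC(=O)c1sc2ccccc2c1Nc1cc(OC)c(OC)c(OC)c1` gives 6390 nM 
Compound 2 `COC(=O)c1sc2cc(C)ccc2c1Nc1cc(OC)c(OC)c(OC)c1` gives 1.2 nM 
Compound 3 `CCOC(=O)c1sc2cccc(C)c2c1Nc1cc(OC)c(OC)c(OC)c1` gives 4150 nM 

Compound 3 lies within the scatter of compound 1, and both stand far above compound 2. Compound 4 `COC(=O)c1sc2cccc(C)c2c1Nc1cc(OC)c(OC)c(OC)c1` differs from compound 3 by one change, (hydrogen in place of methyl on a saturated chain carbon bound to an oxygen next to a carbonyl group), hydrogen in place of methyl on a saturated chain carbon bound to an oxygen next to a carbonyl group, which turns ethoxycarbonyl to methoxycarbonyl.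

Among the measured compounds shown here, the only measured single change, methyl in place of hydrogen on an aromatic carbon, gave a 1.5-fold lower number from compound 1 to compound 3 (0.19 log units; within the scatter) and does not touch this group. For the measured compounds named here, the sole hint is compound 2 at 1.2 nM, which carries methoxycarbonyl but differs from compound 3 in more than that one place. A lower number is therefore expected in this assay, though with little certainty about the size. The expected step is a 5.2-fold lower number from compound 3 to compound 4 (0.71 log units; beyond the scatter) and remains a rough estimate. Compound 4 is estimated at 800 nM (expected range 20 nM to 6000 nM).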

Compound 4, half-maximal inhibitory concentration: 8190 nM
Estimate against measurement, compound 4: 10-fold (1.01 log units) below, and the stated range ends below it.
By their numbers in this assay, from the lowest: compound 2; then compounds 3, 1 and 4 (each within the scatter of the next).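

In this assay, the exchange of ethoxycarbonyl for methoxycarbonyl gives a 2.0-fold higher number from compound 3 to compound 4 (0.30 log units; within the scatter), so on the core of compound 3 this change at the saturated chain carbon leaves the number within the scatter. The ethyl to methyl change alone therefore produces no measurable shift on this core. No measurement shown offers an explanation for this result. The compounds shown leave open whether a carboxylic acid or a longer chain such as propyl in this place would move the number, and whether ethoxycarbonyl and methoxycarbonyl would also match on the core of compound 2.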